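The compounds below may be only part of what the source reports. "The series", "measured", "known", "first", "only" and "open" are said of these compounds alone.

Three compounds sharing one core were tested in a functional assay on SMMC-7721 cells (Homo sapiens) for cytotoxicity, read by MTT assay, with a stated time of 72 h; on this read-out higher numbers stand for weaker inhibition and lower numbers for stronger inhibition. Compound 1 `CC(=O)c1ccc(NC(=O)CSC(=S)N[C@H]2CCOC2=O)cc1` sits at the limit of > 128000 nM in this assay, at which 1 of the 3 values shown sits, and gives > 128000 nM, a limit rather than a number. Compound 2 `CCOC(=O)c1ccc(NC(=O)CSC(=S)N[C@H]2CCOC2=O)cc1` gives 64900 nM in this assay, and compound 3 `O=C(CSC(=S)N[C@H]1CCOC1=O)Nc1ccc(C(=O)/C=C/c2cccc(Cl)c2)cc1` gives 39100 nM. Compound 3 therefore carries the lowest of the two numbers, though its nearest neighbour, compound 2, lies within the scatter of it. The steps among these three, an at least 1.9-fold lower number from compound 1 to compound 2 (0.29 log units; that floor lies within the scatter), an at least 3.2-fold lower number from compound 1 to compound 3 (0.51 log units; beyond the scatter) and a 1.7-fold lower number from compound 2 to compound 3 (0.22 log units; within the scatter), all concern the group on the carbonyl carbon. Compound 4 `O=C(CSC(=S)N[C@H]1CCOC1=O)Nc1ccc(C(=O)/C=C/c2ccc([N+](=O)[O-])cc2)cc1` differs from compound 3 elsewhere: 4-nitrophenyl in place of 3-chlorophenyl on a double-bonded chain carbon bound to a double-bonded chain carbon. Among the measured compounds shown here, none of the measured steps touches the aryl part of that ethenyl chain, so they offer no direct guide to this exchange, and the change is expected to yield no step beyond the scatter. Compound 4 is thus estimated to give 35000 nM in this assay, with a range from 12000 nM to 110000 nM. That estimate corresponds to an expected 1.1-fold lower number from compound 3 to compound 4 (0.05 log units; within the scatter), which stays within the scatter.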

Compound 4, half-maximal inhibitory concentration: > 128000 nM
Compound 4: no number, only a limit; the forecaster's own chance of this, stated with the estimate: 10%; at least 3.6-fold (0.56 log units) between middle value and limit.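

Among the compounds shown here, exchanging 3-chlorophenyl for 4-nitrophenyl on a double-bonded chain carbon bound to a double-bonded chain carbon gives an at least 3.2-fold higher number from compound 3 to compound 4 (0.51 log units; beyond the scatter) in this assay, so the aryl end of the ethenyl chain, which no earlier step touched, can shift this read-out. With ethoxy on the carbonyl carbon as the reference, 2-(4-nitrophenyl)ethenyl gives an at least 1.9-fold higher number from compound 2 to compound 4 (0.29 log units; that floor lies within the scatter), whereas compound 3, with its 2-(3-chlorophenyl)ethenyl, stays within the scatter of compound 2, so the ethenyl chain alone does not settle the outcome. Compound 4 gives a limit rather than a number, and its step from compound 1 cannot be read, as both compounds sit at a limit: the limit of > 128000 nM in this assay, at which 2 of the 4 values shown sit.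

The compounds shown leave open how 4-chlorophenyl or 3-nitrophenyl on this chain would read, and so whether the step follows the nitro group or the numbering on the ring. Going by these compounds, an amine such as 4-aminophenyl in the same place is equally open.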